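The compounds below may be only part of what the source reports. "The series", "measured", "known", "first", "only" and "open" are said of these compounds alone.

Series notes. In an assay on cells for inhibition of cytochrome P450 11B2, mitochondrial (Homo sapiens), read by HPLC, with a stated time of 90 min (on this read-out higher numbers stand for weaker inhibition and lower numbers for stronger inhibition), compound 1 `Fc1ccc2nc(-n3ccnn3)n(C3CC3)c2c1` gives 1060 nM, compound 2 `Fc1cc2nc(-c3cncnc3)n(C3CC3)c2cc1F` gives 22 nM and compound 3 `CC(C)c1ncncc1-c1nc2cc(F)c(F)cc2n1C1CC1` gives 5 nM. Compound 2 thus stands second highest of the three numbers, nearest to compound 3 and far from compound 1. Compound 4 `Fc1cc2nc(-c3cncnc3C(F)F)n(C3CC3)c2cc1F` differs from compound 2 by difluoromethyl in place of hydrogen on an aromatic carbon. Among the measured compounds shown here, the one measured step that bears on this is a 4.4-fold lower number from compound 2 to compound 3 (0.64 log units; beyond the scatter), a change at the same aromatic carbon next to the ring nitrogen, where a larger group entered in place of hydrogen. A step of the same direction and roughly similar size is therefore expected here: a 2.8-fold lower number from compound 2 to compound 4 (0.44 log units; beyond the scatter). Compound 4 is estimated in this assay at 8 nM, with a range from 3 nM to 25 nM.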

Compound 4, half-maximal inhibitory concentration: 18 nM
For compound 4 the middle estimate is 2.3-fold (0.35 log units) below the measured one; the measured number falls inside the stated range.
By their numbers in this assay, from the lowest: compound 3; then compounds 4 and 2 (each within the scatter of the next); then compound 1.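

Difluoromethyl in place of hydrogen on this aromatic carbon next to the ring nitrogen gives a 1.2-fold lower number from compound 2 to compound 4 (0.09 log units; within the scatter) and so shows no change that can be read. Set against isopropyl, the same position gives a 3.6-fold higher number from compound 3 to compound 4 (0.56 log units; beyond the scatter) as its step, so the lower number of compound 3 does not extend to every group entering here. Nothing at hand gives a reason for this difference between the two groups. As far as these compounds go, whether a methyl, a methoxy, an amine or a longer chain on this carbon would track isopropyl or difluoromethyl stays open.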